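The source may hold more compounds than are shown below. What is called first, only, known or untested is meant among the compounds shown, and "the series" means these compounds.

Compound 1 `Cn1c(-c2ccc(-c3cncnc3)cc2)nnc1C1(c2ccc(Cl)cc2)CCC1`: 46%
Compound 2 `Cn1c(-c2ccccc2)nnc1C1(c2ccc(Cl)cc2)CCC1`: 29%
Compound 3 `CCNC(=O)c1ccc(-c2nnc(C3(c4ccc(Cl)cc4)CCC3)n2C)cc1`: 71%

Three compounds share one core and differ only in the group on the para position of the phenyl ring. In a functional assay on the whole organism (strain ICR) for inhibition, with Mus musculus as the target, read by scintillation counting, with a stated time of 4 h, at a dose of 10 mg/kg by the oral route (on this read-out higher numbers stand for more inhibition at the one dose given (going by the name of the read-out) and lower numbers for less inhibition), compound 3 gives 71%, the highest of the three numbers; compound 1 gives 46% and compound 2 gives 29%. Both steps to compound 3 are beyond the scatter: a number 42 percentage points higher from compound 2 to compound 3 (beyond the scatter) and a number 25 percentage points higher from compound 1 to compound 3 (beyond the scatter). Between the two lower compounds, a number 17 percentage points lower from compound 1 to compound 2 (beyond the scatter).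

Compound 4 `Cc1noc(C)c1-c1ccc(-c2nnc(C3(c4ccc(Cl)cc4)CCC3)n2C)cc1` is not yet measured. It differs from compound 3 as follows: 3,5-dimethyl-1,2-oxazol-4-yl in place of ethylcarbamoyl on an aromatic carbon. For the measured compounds named here, the step that bears most closely on this change is the one from compound 1 to compound 3, since the pyrimidin-5-yl group of compound 1, like the entering ring, is an aromatic heterocycle with two hydrogen-bond acceptors and no donor, and a number 25 percentage points higher from compound 1 to compound 3 (beyond the scatter). The ethylcarbamoyl group that leaves carries the only donor among the three, and its replacement by a hydrogen gave a number 42 percentage points higher from compound 2 to compound 3 (beyond the scatter) in reverse. A downward step is therefore expected, a number 23 percentage points lower from compound 3 to compound 4 (beyond the scatter), placing compound 4 near compound 1 rather than compound 3. Compound 4 is estimated at 48%, with a range from 25% to 70%.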

Compound 4, a percentage reported as inhibition, in the whole organism at one dose (the size of the read-out at that dose, not a potency): 63%
For compound 4 the middle estimate is 15 percentage points below the measured one; low and high end bracket the measured number.
By their numbers in this assay, from the lowest: compound 2; then compound 1; then compounds 4 and 3 (each within the scatter of the next).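

In this assay, the 3,5-dimethyl-1,2-oxazol-4-yl group takes the place of ethylcarbamoyl with a number 8 percentage points lower from compound 3 to compound 4 (within the scatter), so at this place, para to a large group, a group with 0 hydrogen-bond donors can stand within the scatter of the ethylcarbamoyl group, which carries 1 hydrogen-bond donor. The new ring also separates from the other ring shown here and from plain hydrogen, with a number 17 percentage points higher from compound 1 to compound 4 (beyond the scatter) and with a number 34 percentage points higher from compound 2 to compound 4 (beyond the scatter), so an aromatic ring at this position does not by itself set the read-out, and the choice of ring matters. Nothing at hand explains why these groups differ in this way.

The compounds shown leave open whether the amide hydrogen of ethylcarbamoyl contributes at all, which dimethylcarbamoyl, with the same carbonyl and no such hydrogen, would test directly. They also leave open how a carboxylic acid, a primary amine or a longer chain on the amide nitrogen would read at this place, and whether the closeness of compound 3 and compound 4 at the one dose given would hold at other doses.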